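The source may report more compounds than this note shows. Statements on the series, on what has been measured and on what is new or still open speak of the compounds shown alone.

Measured so far:
compound 1, `O=C1C=CC(=O)C(c2cc(-c3ccc(C(=O)N4CCC(C(F)(F)F)CC4)s3)on2)=C1`: > 30000 nM
compound 2, `COc1ccc(OC)c(-c2cc(-c3ccc(C(=O)N(C)C)s3)on2)c1`: > 30000 nM

In a functional assay on A549 cells (Homo sapiens) for cytotoxicity, read by XTT assay, with a stated time of 72 h (a higher number here means a weaker inhibitor, a lower number a stronger inhibitor), compound 1 gives only a limit of the assay and no number, > 30000 nM. Compound 2 likewise gives only a limit in this assay, > 30000 nM. Both values sit at the limit of > 30000 nM in this assay, at which 2 of the 2 values shown sit, so compound 2 stands at the top of what this assay reports, with no numeric value to anchor it. Going by the values given here, no step between measured compounds that differ in one place exists, so no measured size of change is available.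

Compound 3, `COc1ccc(OC)c(-c2cc(-c3ccc(C(=O)N4CCC(C(F)(F)F)CC4)s3)on2)c1`, differs from compound 2 by 4-(trifluoromethyl)piperidin-1-yl in place of dimethylamino on a carbonyl carbon. Compound 1 carries the same 4-(trifluoromethyl)piperidin-1-yl amide and shows only a limit in this assay, as compound 2 with the dimethylamino amide does. The expected step from compound 2 to compound 3 is a number no higher from compound 2 to compound 3 (the limit leaves the size open), that is none beyond the scatter, with the value most likely a limit again. Compound 3 is therefore estimated at 30000 nM, within 10000 nM to 100000 nM.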

Compound 3, half-maximal inhibitory concentration: > 30000 nM
Compound 3 ended at the assay's limit (the forecaster's own chance of this, stated with the estimate: 85%); the middle value lies on the limit itself.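

The steps from compound 2 to compound 3 and from compound 1 to compound 3 cannot be read in this assay, as all three compounds give only a limit: the limit of > 30000 nM in this assay, at which 3 of the 3 values shown sit.

The compounds shown leave open how far either exchange changes cytotoxicity: none of them has a numeric value.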